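The source may hold more compounds than are shown below. What is called first, only, known or untested is meant among the compounds shown, and "the series" means these compounds.

In a functional assay on HepG2 cells (Homo sapiens) for cytotoxicity, read by MTT assay, with a stated time of 48 h (a higher number here means a weaker inhibitor, a lower number a stronger inhibitor), compound 1 `CCCCCCCCCCCCCCNC(=O)[C@@H](NC(=O)c1cc2ccccc2o1)[C@@H](C)O` gives 23400 nM. Compound 2 `CCCCCCCCCCCCCCCCCCNC(=O)[C@@H](NC(=O)c1ccccc1)[C@@H](C)O` reaches only a limit of the assay, > 400000 nM. Compound 3 `CCCCCCCCCCCCCCCCCCNC(=O)[C@@H](NC(=O)c1cc2ccccc2o1)[C@@H](C)O` likewise reaches only a limit of the assay, > 200000 nM, so its true number is not known and it stands at the weak end of what was measured. Two measured steps lead to compound 3: an at least 8.5-fold higher number from compound 1 to compound 3 (0.93 log units; beyond the scatter), and a step that the two limits leave unreadable from compound 2 to compound 3. Compound 4 `CCCCCCCCCCCCCCCCCCNC(=O)[C@@H](NS(=O)(=O)c1ccc(C)cc1)[C@@H](C)O` differs from compound 3 by (4-methylphenyl)sulfonyl in place of (1-benzofuran-2-yl)carbonyl on an amine nitrogen. Among the compounds with values here, the only measured step that swaps the group on the carbonyl carbon is unreadable, so no measured step gives a readable size for this change, and the direction is open. The estimated change is a number no higher from compound 3 to compound 4 (the limit leaves the size open). The estimate for compound 4 in this assay is 200000 nM, between 50000 nM and 800000 nM.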

Compound 4, half-maximal inhibitory concentration: 75800 nM
For compound 4 the middle estimate is 2.6-fold (0.42 log units) above the measured one; low and high end bracket the measured number.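

In this assay, within the data shown here, compound 4 is the first compound with the longer chain to give a number rather than a limit. With (4-methylphenyl)sulfonyl on the amine nitrogen, the data show an at least 2.6-fold lower number from compound 3 to compound 4 (0.42 log units; beyond the scatter), and an at least 5.2-fold lower number from compound 2 to compound 4 (0.72 log units; beyond the scatter). From the compounds shown here alone, both steps start from a limit of the assay, so the sulfonyl group's direction is readable, while the true size of each step stays open.

Going by these compounds, whether the same swap would lower the number on the shorter chain of compound 1 remains open. So does the outcome with a methylsulfonyl group or a free amine at this nitrogen.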